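The compounds below may be only part of what the source reports. "The series", "measured", "known", "first", "only" and "open" are said of these compounds alone.

In a functional assay on a cell-free system (plasma, Homo sapiens) for inhibition, with Plasma (Rattus norvegicus) as the target (on this read-out lower numbers stand for stronger inhibition and higher numbers for weaker inhibition), compound 1 (`CSCOc1ccc2c(N3CCNCC3)cc(=O)oc2c1C`) gives 900 nM and compound 2 (`CSCCOc1ccc2c(N3CCNCC3)cc(=O)oc2c1C`) gives 1500 nM. For the measured compounds named here, these are the only two numbers so far, and they lie within the scatter of each other, so compound 2 has no clear rank. Compound 3 (`Cc1c(OCC2CCCN(C)C2)ccc2c(N3CCNCC3)cc(=O)oc12`) keeps the shared core and differs at one place: 1-methylpiperidin-3-yl in place of (methylsulfanyl)methyl on a saturated chain carbon bound to an oxygen on an aromatic ring. Going by the values given here, only one measured step bears on this change: a 1.7-fold higher number from compound 1 to compound 2 (0.22 log units; within the scatter). That step occurred at the same place, but it only altered an open chain, whereas 1-methylpiperidin-3-yl brings in a ring. It therefore offers weak guidance here, and the data give no direction for the new group. No change beyond the scatter is expected, though the uncertainty is wide. The expected step is a 1.3-fold lower number from compound 2 to compound 3 (0.10 log units; within the scatter). The estimated value for compound 3 is 1200 nM, with an expected range of 300 nM to 4500 nM.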

Compound 3, half-maximal inhibitory concentration: 4700 nM
Estimate against measurement, compound 3: 3.9-fold (0.59 log units) below; measured number outside the range, above it.
By their numbers in this assay, from the lowest: compounds 1 and 2 (each within the scatter of the next); then compound 3.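

The two open chains with sulfur did not separate from each other, but a ring at this place, on a saturated chain carbon bound to an oxygen on an aromatic ring, does make a difference. In this assay, 1-methylpiperidin-3-yl brings a 3.1-fold higher number from compound 2 to compound 3 (0.50 log units; beyond the scatter) and a 5.2-fold higher number from compound 1 to compound 3 (0.72 log units; beyond the scatter), so inhibition weakens modestly and this position is not indifferent to the group it carries. No measurement at hand explains why the number rises.

Since 1-methylpiperidin-3-yl differs from the chains in both its ring and its nitrogen, the compounds shown cannot say which of the two goes with the weaker inhibition. A cyclohexyl ring, which has carbons only, and an open-chain dimethylamino group would each carry just one of those two features.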